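Dioxane-benzoyl pyrazolines: fluorophenyl positional change

The source may report more compounds than this note shows. Statements on the series, on what has been measured and on what is new or still open speak of the compounds shown alone.

Measured so far:
- compound 1, `COc1ccc(C2CC(c3ccccc3)=NN2C(=O)c2ccc3c(c2)OCCO3)cc1`: in a functional assay on WM 266-4 cells (Homo sapiens) for inhibition, read by MTT assay, with a stated time of 24 h (on this read-out higher numbers stand for weaker inhibition of growth and lower numbers for stronger inhibition of growth), compound 1 gives 8370 nM
- compound 2, `O=C(c1ccc2c(c1)OCCO2)N1N=C(c2ccccc2)CC1c1ccc(F)cc1`: in this assay compound 2 gives 5210 nM
- compound 3, `O=C(c1ccc2c(c1)OCCO2)N1N=C(c2ccc(Br)cc2)CC1c1ccc(F)cc1`: in this assay compound 3 gives 3260 nM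

Compound 2 sits between the other two on these numbers, with a 1.6-fold lower number from compound 1 to compound 2 (0.21 log units; within the scatter) and a 1.6-fold lower number from compound 2 to compound 3 (0.20 log units; within the scatter) both within the scatter, so the three compounds cannot be ordered against one another.

Compound 4, `O=C(c1ccc2c(c1)OCCO2)N1N=C(c2ccccc2)CC1c1cccc(F)c1`, is not yet measured. The change from compound 2 is 3-fluorophenyl in place of 4-fluorophenyl on a saturated ring carbon. Among the compounds with values here, no measured step moves a group from one ring position to another; the two steps available exchange substituents on an aromatic carbon, and both stayed within the scatter. Within the data shown here, the change to compound 4 therefore has no direct precedent, and there is no basis in the measured compounds for expecting a shift beyond the scatter in this assay.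

Compound 4 is expected to give about 5500 nM in this assay, with a range of 2500 nM to 12000 nM, which corresponds to an expected step of a 1.1-fold higher number from compound 2 to compound 4 (0.02 log units; within the scatter).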

Compound 4, concentration for 50% growth inhibition: 1840 nM
For compound 4 the middle estimate is 3.0-fold (0.48 log units) above the measured one; measured number below the stated range.
By their numbers in this assay, from the lowest: compounds 4, 3, 2 and 1 (each within the scatter of the next, the first and the last beyond it).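

In this assay, within the data shown here, the aryl group on the saturated ring carbon is the first site where a single change goes beyond the scatter: moving the fluorine within the ring gives a 2.8-fold lower number from compound 2 to compound 4 (0.45 log units; beyond the scatter) with no change in atom count. Replacing 4-methoxyphenyl with 3-fluorophenyl at this carbon gives a 4.5-fold lower number from compound 1 to compound 4 (0.66 log units; beyond the scatter), while replacing it with 4-fluorophenyl gives a 1.6-fold lower number from compound 1 to compound 2 (0.21 log units; within the scatter), so among these compounds the place of the fluorine on the ring, not its presence alone, separates the numbers. Nothing measured here explains the shift.

On these data alone, it remains open whether 3-fluorophenyl gives a similar step alongside the bromo group of compound 3. As far as these compounds go, it is also open how an amine or a carboxylic acid on this phenyl ring would read out in this assay.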